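This account rests on a few compounds, and the source may have more. Where it says the series, first, only, none or still open, it means among the compounds named here.

Measured in an assay on isolated protein for inhibition of Ephrin type-A receptor 2 (Homo sapiens), read by thermal shift assay, tested at 10 uM; on this read-out lower numbers stand for weaker stabilisation of the target and higher numbers for stronger stabilisation of the target against heat:
compound 1 `Cc1ccccc1NC(=O)Nc1cc(C(C)(C)C)nn1-c1ccccc1` gives 1.2 degrees C
compound 2 `CC(C)(C)c1cc(NC(=O)Nc2ccc(F)cc2)n(-c2ccccc2)n1` gives -2.2 degrees C
compound 3 `Cc1cc(C)cc(NC(=O)Nc2cc(C(C)(C)C)nn2-c2ccccc2)c1` gives 0.7 degrees C

Compound 1 stands highest of the three in this assay; compound 3 sits within the scatter of it (a number 0.50 degrees C lower from compound 1 to compound 3 (within the scatter)), while compound 2 lies beyond it (a number 3.4 degrees C lower from compound 1 to compound 2 (beyond the scatter)). Compound 4 `CC(C)(C)c1cc(NC(=O)Nc2ccc(F)c(F)c2)n(-c2ccccc2)n1` differs from compound 1 by 3,4-difluorophenyl in place of 2-methylphenyl on an amide-type nitrogen. The step that bears most on this is a number 3.4 degrees C lower from compound 1 to compound 2 (beyond the scatter), where 4-fluorophenyl likewise took the place of 2-methylphenyl; a number 2.9 degrees C higher from compound 2 to compound 3 (beyond the scatter) points the same way, 3,5-dimethylphenyl over 4-fluorophenyl. For compound 4 a drop of similar size is therefore expected in this assay, about a number 3.2 degrees C lower from compound 1 to compound 4 (beyond the scatter). Compound 4 is estimated at -2 degrees C, within the range -4 degrees C to 0.5 degrees C.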

Compound 4, shift of the target's melting temperature: 2.2 degrees C
For compound 4 the middle estimate is 4.2 degrees C below the measured one; the whole stated range lies below it.
By their numbers in this assay, from the lowest: compound 2; then compounds 3, 1 and 4 (each within the scatter of the next, the first and the last beyond it).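

In this assay, fluoro in place of hydrogen on an aromatic carbon gives (a number 4.4 degrees C higher from compound 2 to compound 4 (beyond the scatter)), so a fluorinated phenyl on the amide-type nitrogen is not poor as such: of the two shown, only 4-fluorophenyl gives the low number. 3,4-difluorophenyl stands clear of 3,5-dimethylphenyl (a number 1.5 degrees C higher from compound 3 to compound 4 (beyond the scatter)) but cannot be separated from 2-methylphenyl (a number 1.0 degrees C higher from compound 1 to compound 4 (within the scatter)). Nothing at hand explains the size of the step from the added fluoro.

As far as these compounds go, whether 3-fluorophenyl alone would match 3,4-difluorophenyl stays open. So does the effect of an amine or a carboxylic acid on this phenyl ring.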